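The source may hold more compounds than are shown below. What is called first, only, known or untested is meant among the compounds shown, and "the series" means these compounds.

The measured compounds and what is known of them:

- compound 1, `COC(=O)c1ccc(N(Cc2cnc(C3CCCCC3)cn2)C(=O)[C@H]2CCN2S(=O)(=O)c2c(F)c(F)c(F)c(F)c2F)cc1O`: in an ADME assay on MCF-10A cells (Homo sapiens) for cytotoxicity, with a stated time of 72 h (a lower number here means that less compound is needed, a higher number that more compound is needed for the effect), compound 1 gives 3800 nM.
- compound 2, `CONC(=O)c1ccc(N(Cc2ccc(C3CCCCC3)cn2)C(=O)[C@H]2CCN2S(=O)(=O)c2c(F)c(F)c(F)c(F)c2F)c(F)c1`: in this assay compound 2 gives "not determined" (no result reported), that is, no result was reported for compound 2.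

Among the measured compounds shown here, compound 2 therefore stands without a number of its own; the only measured anchor is compound 1, and compound 1 and compound 2 differ in more than one place, so no single step between them can be given. Compound 3, `O=C1NC(=O)c2cc(N(Cc3ccc(C4CCCCC4)cn3)C(=O)[C@H]3CCN3S(=O)(=O)c3c(F)c(F)c(F)c(F)c3F)ccc21`, is the next compound to be measured. Compared with compound 2, the change is a group of 11 heavy atoms (8 carbon, 1 nitrogen, 2 oxygen; one five-membered non-aromatic ring with 1 hetero atom, one six-membered aromatic ring of carbon only) in place of a group of 12 heavy atoms (8 carbon, 1 nitrogen, 2 oxygen, 1 fluorine; one six-membered aromatic ring of carbon only), on an amide-type nitrogen. For the measured compounds named here, no step between measured compounds is available, so there is nothing to say how large a move this kind of change brings in this assay. The expectation is that the step from compound 2 to compound 3 in this assay is small, with no clear direction and likely within the usual scatter, and that compound 3 lands in the same broad region as compound 1. Compound 3 is estimated to give about 4000 nM, expected to lie between 1000 nM and 20000 nM.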

Compound 3, half-maximal effective concentration: 8100 nM
Estimate against measurement, compound 3: 2.0-fold (0.31 log units) below; low and high end bracket the measured number.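

No new step can be read: in this assay compound 2 has no reported result, and compound 3 differs from compound 1 in more than one place. Nothing measured here helps explain the value of compound 3. The compounds shown leave open how far replacing the 2-fluoro-4-(methoxycarbamoyl)phenyl group moves the result in this assay.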